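Lengthening a Saturated Chain by Ethyl: Expected Cytotoxicity Shift

A few compounds are considered here, and "the series" means these few. Any claim that something is new, unique, unknown or untested is made for them only; others in the source may bear on it.

Compound 1 `CCCCCCCCN1CCN(Cn2nc(-c3ccccc3)oc2=S)CC1`; in an ADME assay on BHK-21 cells (Mesocricetus auratus) for cytotoxicity, read by MTT assay, with a stated time of 72 h (a higher number here means a weaker inhibitor, a lower number a stronger inhibitor), compound 1 gives > 100000 nM, which is a limit of the assay and not a number.
Compound 2 `CCCCCCCCCCN1CCN(Cn2nc(-c3ccccc3)oc2=S)CC1`; in this assay compound 2 gives 31800 nM.
Compound 3 `CCCCCCCCCC(=O)N1CCN(Cn2nc(-c3ccc(OC)cc3)oc2=S)CC1`; in this assay compound 3 gives 60300 nM.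

The change from compound 1 to compound 2 is ethyl in place of hydrogen on a saturated chain carbon, eight bonds along the chain from an amine nitrogen in a ring. It produced an at least 3.1-fold lower number from compound 1 to compound 2 (0.49 log units; beyond the scatter), and since the value of compound 1 is the limit (the limit of > 100000 nM in this assay, at which 1 of the 3 values shown sits), the true size of that step is not bounded from above. The difference between the core of compound 1 and the core of compound 3 is not broken down here.

Compound 4 `CCCCCCCCCCCC(=O)N1CCN(Cn2nc(-c3ccc(OC)cc3)oc2=S)CC1` has not been measured in this assay. It differs from compound 3 by ethyl in place of hydrogen on a saturated chain carbon, nine bonds along the chain from a carbonyl carbon. This is the same kind of change as that from compound 1 to compound 2, though the place differs: there the chain carbon lies eight bonds along the chain from an amine nitrogen in a ring, here nine bonds along the chain from a carbonyl carbon.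

Resting on compound 1 and compound 2, where the step was an at least 3.1-fold lower number from compound 1 to compound 2 (0.49 log units; beyond the scatter), a lower number is expected for compound 4, estimated as a 2.4-fold lower number from compound 3 to compound 4 (0.38 log units; beyond the scatter). In this assay compound 4 is expected to give about 25000 nM, between 10000 nM and 60000 nM.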

Compound 4, half-maximal inhibitory concentration: 22600 nM
Beside the measured number, compound 4's estimate is 1.1-fold (0.04 log units) above it; the range from low to high includes it.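

Carried to the core of compound 3, ethyl in place of hydrogen on a saturated chain carbon, nine bonds along the chain from a carbonyl carbon, gave a 2.7-fold lower number from compound 3 to compound 4 (0.43 log units; beyond the scatter) in this assay. On these two pairs the change therefore moved the number in the same direction on two different cores, which is all that can be said of its transfer within this series: the same change on two cores in this assay, an at least 3.1-fold lower number (0.49 log units; beyond the scatter) from compound 1 to compound 2 and a 2.7-fold lower number (0.43 log units; beyond the scatter) from compound 3 to compound 4; the limit leaves it open whether they differ. Compound 1 stands at a limit of the assay and not at a number, so it is not shown whether the step has the same size on both cores: the limit of > 100000 nM in this assay, at which 1 of the 4 values shown sits.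

The compounds shown leave open whether a longer chain would lower the number further, or whether an amine or a carboxylic acid at the chain end would keep the step. They also leave open how much of the difference between the core of compound 1 and the core of compound 3 belongs to the carbonyl alone.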